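This account rests on a few compounds, and the source may have more. Where it says the series, first, only, none or still open, it means among the compounds named here.

Working notes on the sulfonamide series.

Compound 1 `COc1ccc(S(=O)(=O)NCCN2CCC(CCC(=O)c3cc(Cl)c(N)cc3OC)CC2)cc1Cl` gives 85% in an assay on HEK293 cells for displacement of a labelled ligand from 5-hydroxytryptamine receptor 6 (Homo sapiens), with a stated time of 60 min, tested at 1 uM, in the presence of a further agent that is not named here; on this read-out higher numbers stand for a stronger effect at the one concentration tested and lower numbers for a weaker effect. Compound 2 `COc1ccc(S(=O)(=O)NCCN2CCC(CCC(=O)c3cc(Cl)c(N)cc3OC)CC2)cc1` gives 52%, and compound 3 `COc1ccc(S(=O)(=O)NCCN2CCC(CCC(=O)c3cc(Cl)c(N)cc3OC)CC2)c(OC)c1` gives 45%. Of the three numbers, compound 3 is the lowest: the change a number 7 percentage points lower from compound 2 to compound 3 (within the scatter) lies within the scatter, whereas a number 40 percentage points lower from compound 1 to compound 3 (beyond the scatter) is beyond it, as is a number 33 percentage points lower from compound 1 to compound 2 (beyond the scatter).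

Compound 4 `COc1cc(N)c(Cl)cc1C(=O)CCC1CCN(CCNS(=O)(=O)c2ccc(NC(C)=O)cc2)CC1` differs from compound 3 in one place: 4-acetamidophenyl in place of 2,4-dimethoxyphenyl on a sulfonyl sulfur. Within the data shown here, the only measured step that exchanges the whole aryl group on the sulfonyl sulfur is a number 40 percentage points lower from compound 1 to compound 3 (beyond the scatter), which was large; the smaller steps of a number 33 percentage points lower from compound 1 to compound 2 (beyond the scatter) and a number 7 percentage points lower from compound 2 to compound 3 (within the scatter) alter one substituent on that ring at a time. Among the measured compounds shown here, none of them introduces an acetamido group, so no direct precedent exists for the direction of this change, only evidence that the aryl group on the sulfonyl sulfur matters for this read-out.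

Compound 4 is therefore expected to give 55% in this assay, between 25% and 80%. The step expected for compound 4 is a number 10 percentage points higher from compound 3 to compound 4 (within the scatter), a modest rise with a wide uncertainty.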

Compound 4, a percentage reported as inhibition, at one concentration (the size of the read-out at that concentration, not a potency): 67%
Estimate against measurement, compound 4: 12 percentage points below, within the range that was stated.
By their numbers in this assay, from the lowest: compounds 3 and 2 (each within the scatter of the next); then compound 4; then compound 1.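

On the sulfonyl sulfur, 4-acetamidophenyl gives a number clearly apart from both the methoxy-substituted rings and the chloro-bearing ring in this assay (a number 22 percentage points higher from compound 3 to compound 4 (beyond the scatter); a number 15 percentage points higher from compound 2 to compound 4 (beyond the scatter); a number 18 percentage points lower from compound 1 to compound 4 (beyond the scatter)). Among the earlier compounds, only the chloro of compound 1 set one ring apart from the others; acetamido in place of methoxy now shows that a second substituent can also raise the number beyond the scatter, though not as far as compound 1. No measurement among the data shown bears on why this exchange raises the number.

On these data alone, it remains open whether the amide hydrogen or the carbonyl of the acetamido group carries this rise. Also open, as far as these compounds go, is whether chloro and acetamido on one ring would add up, and how an amino group or a carboxylic acid in place of acetamido would compare.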